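The source may report more compounds than this note shows. Statements on the series, on what has been measured and on what is new or still open speak of the compounds shown alone.

Measured compounds in a functional assay on DU-145 cells (Homo sapiens) for cytotoxicity, read by sulforhodamine B assay, with a stated time of 48 h; on this read-out higher numbers stand for weaker inhibition of growth and lower numbers for stronger inhibition of growth:
compound 1 `N#Cc1ccc(Nc2nc(Oc3ccnc4ccccc34)nc(N3CCN(c4ccccc4Cl)CC3)n2)cc1C(F)(F)F` gives 92600 nM
compound 2 `CCN1CCN(c2nc(Nc3ccc(C#N)c(C(F)(F)F)c3)nc(Oc3ccnc4ccccc34)n2)CC1` gives 86600 nM

Compound 2 holds the lowest of the two numbers in this assay, with compound 1 nearest; the two stand within the scatter of each other, so no order between them can be read.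

Among the measured compounds shown here, the only measured step on the shared core is a 1.1-fold lower number from compound 1 to compound 2 (0.03 log units; within the scatter). Swapping an aromatic ring for a short chain on the amine nitrogen of the piperazine left the number essentially unchanged.

Compound 3 `N#Cc1ccc(Nc2nc(Oc3ccnc4ccccc34)nc(N3CCN(c4ccccn4)CC3)n2)cc1C(F)(F)F` is not yet measured. It differs from compound 2 in one place: pyridin-2-yl in place of ethyl on an amine nitrogen in a ring. This reverses the direction of the measured step, returning an aromatic ring to the same nitrogen, now a six-membered ring with one hetero atom instead of the 2-chlorophenyl of compound 1. Because a 1.1-fold lower number from compound 1 to compound 2 (0.03 log units; within the scatter) lay within the scatter, no step beyond the scatter is expected in this assay.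

For compound 3 the expected step is a 1.0-fold higher number from compound 2 to compound 3 (0.02 log units; within the scatter), and the estimated value is 90000 nM, with a range from 35000 nM to 230000 nM.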

Compound 3, concentration for 50% growth inhibition: 85900 nM
Estimate against measurement, compound 3: 1.0-fold (0.02 log units) above, and the stated range covers the measured number.
By their numbers in this assay, from the lowest: compounds 3, 2 and 1 (each within the scatter of the next).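

Working from the piperazine amine nitrogen in this assay, the step of a 1.0-fold lower number from compound 2 to compound 3 (0.00 log units; within the scatter) shows that pyridin-2-yl in place of ethyl, which brings one six-membered aromatic ring with 1 hetero atom and 1 hydrogen-bond acceptor, leaves the number within the scatter. The step of a 1.1-fold lower number from compound 1 to compound 3 (0.03 log units; within the scatter) adds a comparison the earlier pair could not give, between two aromatic groups on this nitrogen, pyridin-2-yl in place of 2-chlorophenyl, and this too stays within the scatter. Across ethyl, 2-chlorophenyl and pyridin-2-yl, then, no order can be read at this position in this assay, and no measurement available here bears on the reason for this.

Still open, from the compounds shown here alone, is whether a carboxylic acid, or a longer chain ending in an amine, on this same nitrogen would give a step beyond the scatter. Also open, going by these compounds, is whether a change elsewhere on the shared core, such as replacing the nitrile, would move the number where these three groups on the piperazine do not.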